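The compounds below may be only part of what the source reports. "The series", "measured", "known", "first", "only" and "open" are said of these compounds alone.

Three compounds share one core and differ only in the group joined to the amine nitrogen through a carbonyl carbon. Compound 1 `CC(O)c1cccc(C(=O)N[C@@H](C)Cn2ccc(-c3ccc(C#N)c(Cl)c3)n2)c1` carries a 3-(1-hydroxyethyl)phenyl on that carbonyl carbon, and in a functional assay on LNCaP cells (Homo sapiens) for antiproliferative activity, read by CCK-8 assay, with a stated time of 6 days (on this read-out higher numbers stand for weaker inhibition and lower numbers for stronger inhibition), compound 1 gives 2280 nM. Compound 2 `COc1ccc(C(=O)N[C@@H](C)Cn2ccc(-c3ccc(C#N)c(Cl)c3)n2)cc1` carries a 4-methoxyphenyl there, and in this assay compound 2 gives 3410 nM. Compound 3 `C[C@@H](Cn1ccc(-c2ccc(C#N)c(Cl)c2)n1)NC(=O)C1CC(=O)C1` carries a 3-oxocyclobutyl, and in this assay compound 3 gives 3040 nM. The steps among them are small: a 1.5-fold higher number from compound 1 to compound 2 (0.17 log units; within the scatter), a 1.3-fold higher number from compound 1 to compound 3 (0.12 log units; within the scatter) and a 1.1-fold lower number from compound 2 to compound 3 (0.05 log units; within the scatter). Compound 3 thus stands second highest of the three numbers, yet every step lies within the scatter, so the three cannot be told apart.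

Compound 4 `C[C@@H](Cn1ccc(-c2ccc(C#N)c(Cl)c2)n1)Nc1ncnc2nc[nH]c12` alters the linkage itself: a group of 9 heavy atoms (5 carbon, 4 nitrogen; one five-membered aromatic ring with 2 hetero atoms, one six-membered aromatic ring with 2 hetero atoms) in place of a group of 7 heavy atoms (5 carbon, 2 oxygen; one four-membered non-aromatic ring of carbon only), on an amine nitrogen. The carbonyl is gone, and a group with one five-membered aromatic ring with 2 hetero atoms and one six-membered aromatic ring with 2 hetero atoms sits directly on the amine nitrogen. Among the measured compounds shown here, none of the measured steps tests such a change; each only swaps one group on a carbonyl carbon for another, and each stays within the scatter. They show that what hangs on the carbonyl barely moves the number, but say nothing about removing it. The expected step is a 1.0-fold lower number from compound 3 to compound 4 (0.01 log units; within the scatter). For compound 4 the estimated value is 3000 nM, with a range from 800 nM to 12000 nM.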

Compound 4, half-maximal inhibitory concentration: 960 nM
For compound 4 the middle estimate is 3.1-fold (0.49 log units) above the measured one; measured number inside the range.
By their numbers in this assay, from the lowest: compound 4; then compounds 1, 3 and 2 (each within the scatter of the next).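

Taking away the (3-oxocyclobutyl)carbonyl and setting the group with a five-membered and a six-membered aromatic ring directly on the amine nitrogen gives the only step in this set that clears the scatter: a 3.2-fold lower number from compound 3 to compound 4 (0.50 log units; beyond the scatter). The swaps on the carbonyl carbon left the numbers of compounds 1, 2 and 3 indistinguishable, whereas this change to the amine nitrogen moves the number, modestly, towards stronger inhibition, so the position is not indifferent to what it carries. Nothing presented here bears on the reason for this shift.

This single step removes the carbonyl and brings in the two aromatic rings together, so the compounds shown cannot separate the effect of losing the carbonyl from that of gaining the new group. From the compounds shown here alone, whether a plain phenyl ring or a single six-membered aromatic ring with 2 hetero atoms, placed directly on the amine nitrogen, would give a similar number remains open, as does whether the hydrogen on the five-membered ring matters, which an added methyl group there would test.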